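Ring sulfur and a halogen swap in antiproliferative cells

The compounds below may be only part of what the source reports. "The series", "measured", "known", "first", "only" and "open" are said of these compounds alone.

Compound 1 `NC1=NC2(CCOCC2)N(OCCCOc2ccc(Cl)cc2)C(N)=N1` and compound 2 `NC1=NC2(CCOCC2)N(OCCCOc2cccc(Br)c2)C(N)=N1` share one core and differ only in the aromatic group at the end of the chain. In a functional assay on A549 cells (Homo sapiens) for antiproliferative activity, read by MTT assay, with a stated time of 72 h (on this read-out higher numbers stand for weaker inhibition and lower numbers for stronger inhibition), compound 1 gives 360 nM, while compound 2 gives 160 nM. The change 4-chlorophenyl in place of 3-bromophenyl on an oxygen on a saturated carbon thus gave a 2.3-fold higher number from compound 2 to compound 1 (0.35 log units; beyond the scatter). Compound 3 `NC1=NC2(CCSCC2)N(OCCCOc2cccc(Br)c2)C(N)=N1` carries a second core, and the difference between the two cores is not broken down here; in this assay compound 3 gives 50 nM, the lowest of the three numbers.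

Compound 4 `NC1=NC2(CCSCC2)N(OCCCOc2ccc(Cl)cc2)C(N)=N1` joins the core of compound 3 to the aromatic group of compound 1, the change 4-chlorophenyl in place of 3-bromophenyl on an oxygen on a saturated carbon being the same change that led from compound 2 to compound 1, at the same place. If it carries over, the expected step is a 2.3-fold higher number from compound 3 to compound 4 (0.36 log units; beyond the scatter), resting on compound 2 and compound 1, whose step was a 2.3-fold higher number from compound 2 to compound 1 (0.35 log units; beyond the scatter). On that basis compound 4 is expected to give about 115 nM in this assay, most likely between 55 nM and 240 nM.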

Compound 4, half-maximal inhibitory concentration: 580 nM
Compound 4: middle estimate off by 5.0-fold (0.70 log units), on the low side; the measured number lies above the stated range.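

On the core of compound 3, putting 4-chlorophenyl in place of 3-bromophenyl gave in this assay a 12-fold higher number from compound 3 to compound 4 (1.06 log units; beyond the scatter), so the change raises the number on both cores, but the size of the step does not carry over: the same change on two cores in this assay, a 2.3-fold higher number (0.35 log units; beyond the scatter) from compound 2 to compound 1 and a 12-fold higher number (1.06 log units; beyond the scatter) from compound 3 to compound 4, 5.2-fold (0.71 log units) apart, beyond the scatter of two such steps

Within these two pairs, the step seen on one core gave the direction on the other but was no reliable guide to its size. The data do not show why the two steps differ, and 3-bromophenyl and 4-chlorophenyl differ in both the halogen and its place on the ring, which these pairs do not separate, nor do they show how the change behaves on any further core.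

The compounds shown leave open whether 3-chlorophenyl or 4-bromophenyl, on each of the two cores, would tell the effect of the halogen from that of its place. They also leave open whether a longer chain in place of the present one would keep the two steps this far apart.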